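The source may report more compounds than this note shows. Statements on the series, on what has been measured and on what is new or still open speak of the compounds shown alone.

Two compounds of this series have a measured value. Compound 1 `Cc1ccc(C(=O)CC(SCC(=O)O)C(=O)O)cc1C` gives 3810 nM in a functional assay on HeLa cells (Homo sapiens); a higher number here means a weaker inhibitor, a lower number a stronger inhibitor. Compound 2 `Cc1ccc(C(=O)CC(SCC(=O)O)C(=O)O)cc1` differs from it by hydrogen in place of methyl on an aromatic carbon, and in this assay compound 2 gives 17300 nM. That change produced a 4.5-fold higher number from compound 1 to compound 2 (0.66 log units; beyond the scatter). Within the data shown here, compound 2 therefore stands with the highest of the two numbers so far, that is, as the weaker inhibitor of the pair.

Compound 3 `CCCCc1ccc(C(=O)CC(SCC(=O)O)C(=O)O)cc1` is not yet measured. Compared with compound 2 it carries propyl in place of hydrogen on a saturated chain carbon bound to an aromatic carbon, so the methyl on the shared core becomes a butyl chain. Among the measured compounds shown here, the only measured step that bears on this, the loss of a methyl from compound 1 to compound 2, points in one direction: less carbon on the aromatic part went with a higher number. Adding carbon at a different position does not have to behave the same way, so the expected step is modest and uncertain: from compound 2 to compound 3 a step of a 2.2-fold lower number from compound 2 to compound 3 (0.33 log units; beyond the scatter) toward a lower number is expected. Compound 3 is accordingly estimated at 8000 nM in this assay, within a range from 2500 nM to 25000 nM.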

Compound 3, half-maximal inhibitory concentration: 1910 nM
The estimate for compound 3 lay 4.2-fold (0.62 log units) above the measured number, outside the stated range (below it).
By their numbers in this assay, from the lowest: compounds 3 and 1 (each within the scatter of the next); then compound 2.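

In this assay, lengthening the methyl of compound 2 to a butyl chain gives a 9.1-fold lower number from compound 2 to compound 3 (0.96 log units; beyond the scatter). This shows that the chain carbon bound to an aromatic carbon can carry propyl in place of hydrogen and that the number falls clearly with this change, whereas the earlier pair spoke only to a methyl on an aromatic carbon. Both steps shown so far link more carbon on the aromatic part to a lower number, and neither goes against that link, but two steps at two different places are too few to make it a rule, and nothing at hand explains the size of this step.

The compounds shown leave open how the number changes along the series from methyl to butyl, and whether it would keep falling with a longer chain such as hexyl or octyl. They also leave open whether the effect depends on an unbranched chain, which a tert-butyl group could test, or whether a chain ending in an amine or a hydroxyl group would give a similar number.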